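Nitro on the pendant phenyl of the methoxy analogue

The source may report more compounds than this note shows. Statements on the series, on what has been measured and on what is new or still open speak of the compounds shown alone.

Compound 2 `COC1Cc2cc(-c3ccccc3)sc2C2(CCN(Cc3ccccc3)CC2)O1` carries the highest number of the two measured in an assay on membranes from brain for displacement of a labelled ligand from Sigma non-opioid intracellular receptor 1 (Cavia porcellus), read by scintillation counting, with a stated time of 120 min; a higher number here means a weaker inhibitor, a lower number a stronger inhibitor; compound 2 gives 16 nM. Its nearest neighbour is compound 1 `c1ccc(CN2CCC3(CC2)OCCc2cc(-c4ccccc4)sc23)cc1`, which in this assay gives 2.4 nM. For the measured compounds named here, the single measured step, a 6.7-fold higher number from compound 1 to compound 2 (0.82 log units; beyond the scatter), concerns a methoxy in place of hydrogen on a saturated ring carbon of the shared core. Compound 3 `COC1Cc2cc(-c3ccc([N+](=O)[O-])cc3)sc2C2(CCN(Cc3ccccc3)CC2)O1` differs from compound 2 by nitro in place of hydrogen on an aromatic carbon. Going by the values given here, no measured step touches the aromatic ring of the shared core, so the methoxy step is the only reference and it does not bear directly on this change. With nothing shown that moves the number far, a step of at most modest size is expected, in either direction. Compound 3 is estimated to give 20 nM, with a range from 7 nM to 60 nM. The expected step is therefore a 1.3-fold higher number from compound 2 to compound 3 (0.10 log units; within the scatter), which is small.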

Compound 3, inhibition constant: 16 nM
Estimate against measurement, compound 3: 1.3-fold (0.10 log units) above; low and high end bracket the measured number.
By their numbers in this assay, from the lowest: compound 1; then compounds 2 and 3 (each within the scatter of the next).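

In this assay, phenyl to 4-nitrophenyl on the methoxy analogue reads as a step with no movement (no change at the digits printed from compound 2 to compound 3 (within the scatter)), so a nitro group on this aromatic carbon, para to a large group, is accepted in this one pair. The earlier compounds shown here spoke only to the saturated ring carbon, where the step lies beyond the scatter (a 6.7-fold higher number from compound 1 to compound 2 (0.82 log units; beyond the scatter)); the pendant phenyl now has a reading of its own, for this one group. Nothing measured bears on why the number holds, so the result stands as a bare observation.

As far as these compounds go, whether an amine or a carboxylic acid at the same place would also leave the number in place stays open. So does whether nitro reads the same on the core of compound 1, without the methoxy.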